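Methoxy added to the benzyl ring of a thiomethyl quinazoline

This account rests on a few compounds, and the source may have more. Where it says the series, first, only, none or still open, it means among the compounds named here.

Measured compounds:
Compound 1 `COc1ccc(CNc2nc([Se]C)nc3ccccc23)cc1`, a functional assay on HT-29 cells (Homo sapiens) for cytotoxicity, read by MTT assay, with a stated time of 72 h; on this read-out lower numbers stand for stronger inhibition of growth and higher numbers for weaker inhibition of growth: 73600 nM
Compound 2 `COc1ccc(CNc2nc([SeH])nc3ccccc23)cc1`, this assay: 71600 nM
Compound 3 `CSc1nc(NCc2ccccc2)c2ccccc2n1`, this assay: 36500 nM

Compound 3 gives the lowest of the three numbers in this assay, yet its gap to compound 2 and to compound 1 lies within the usual scatter, so no ordering among the three can be claimed. Compound 4 `COc1ccc(CNc2nc(SC)nc3ccccc23)cc1` has not been measured. It differs from compound 3 by methoxy in place of hydrogen on an aromatic carbon, the methoxy sitting on an aromatic carbon of a six-membered aromatic ring of carbon only, para to a large group.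

Among the measured compounds shown here, the only single-place step measured, a 1.0-fold lower number from compound 1 to compound 2 (0.01 log units; within the scatter), concerns the selenium substituent and does not bear on adding a methoxy. Compound 1, which carries the same methoxy but selenium in place of sulfur, and compound 3 show values that sit within the scatter of each other, which gives no sign that the methoxy shifts the read-out. The step of a 1.4-fold higher number from compound 3 to compound 4 (0.14 log units; within the scatter) is therefore expected to stay within the scatter. Compound 4 is estimated at 50000 nM, with a range from 20000 nM to 130000 nM.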

Compound 4, concentration for 50% growth inhibition: 70200 nM
Beside the measured number, compound 4's estimate is 1.4-fold (0.15 log units) below it; measured number inside the range.
By their numbers in this assay, from the lowest: compounds 3, 4, 2 and 1 (each within the scatter of the next).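

In this assay, among the compounds shown here, methoxy in place of hydrogen on an aromatic carbon, para to a large group, gives a 1.9-fold higher number from compound 3 to compound 4 (0.28 log units; within the scatter) as the first direct reading of this change, and the step does not separate the two compounds. With the methoxy present, exchanging the selenium-bearing group for the sulfur-and-carbon group gives a 1.0-fold lower number from compound 1 to compound 4 (0.02 log units; within the scatter) and, from the compound with a lone selenium atom, a 1.0-fold lower number from compound 2 to compound 4 (0.01 log units; within the scatter) with no separation in either case. Nothing measured here accounts for these results.

As far as these compounds go, whether an amine, a carboxylic acid or a longer chain on the same aromatic carbon would give a step beyond the scatter remains open. So does whether methoxy on another carbon of that ring would read the same as it does here.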